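The compounds below may be only part of what the source reports. "The series", "measured", "known", "first", "only" and "open" are said of these compounds alone.

Of the compounds shown here, three built on one shared core have been tested in a functional assay on PANC-1 cells (Homo sapiens) for inhibition, read by MTT assay, with a stated time of 24 h, tested at 10 uM; a lower number here means less inhibition, a higher number more inhibition at the concentration tested (going by the name of the read-out). Compound 1 `CC(C)=CCC/C(C)=C/CC1Cc2c(O)cc(=O)n(CCCO)c2CC1(C)C` carries a free hydroxyl on its aromatic ring and gives 0%. Compound 2 `CC(C)=CCC/C(C)=C/COc1cc(=O)n(CCCO)c2c1CC(CC=C(C)C)C(C)(C)C2` carries an ether on that ring and gives 18.4%, the highest of the three numbers; its gap to compound 1 lies beyond the usual scatter of such measurements. Compound 3 `CC(C)=CCC1Cc2c(OCCCNS(=O)(=O)c3ccc(C(F)(F)F)cc3)cc(=O)n(CCCO)c2CC1(C)C`, which also carries an ether on that ring, gives 0%, again a gap to compound 2 beyond the scatter. Among these three, only compound 2 shows an inhibition that stands clearly apart from nothing.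

Compound 4 `CC(C)=CCC1Cc2c(OCCCNC(=O)c3ccco3)cc(=O)n(CCCO)c2CC1(C)C` has not yet been measured. It is built from compound 2 by one change: 2-(((furan-2-yl)carbonyl)amino)ethyl in place of 2,6-dimethylhepta-1,5-dien-1-yl on a saturated chain carbon bound to an oxygen on an aromatic ring. The leaving group is a hydrocarbon chain with two double bonds outside aromatic rings; the entering group brings one five-membered aromatic ring with one hetero atom, one hydrogen-bond donor and two hydrogen-bond acceptors.

For the measured compounds named here, no measured pair here differs in exactly one place, so no direct step can be read off. Compound 3, whose ether also ends in a nitrogen-bearing group, gives 0%, and compound 1 gives 0%. The expected step of a number 15.4 percentage points lower from compound 2 to compound 4 (beyond the scatter) is therefore downward and beyond the scatter, because compound 3 gives 0%. Compound 4 is estimated at 3%, within a range from 0% to 15%.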

Compound 4, a percentage reported as inhibition, at one concentration (the size of the read-out at that concentration, not a potency): 4.3%
Beside the measured number, compound 4's estimate is 1.3 percentage points below it; the measured number falls inside the stated range.
By their numbers in this assay, from the lowest: compounds 1, 3 and 4 (each within the scatter of the next); then compound 2.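

In this assay, for the compounds shown here, putting 2-(((furan-2-yl)carbonyl)amino)ethyl in place of 2,6-dimethylhepta-1,5-dien-1-yl on a saturated chain carbon bound to an oxygen on an aromatic ring gives a number 14.1 percentage points lower from compound 2 to compound 4 (beyond the scatter), which is the first comparison here in which only one place changes, and it shows that the number responds to what this position carries. The change swaps a ringless hydrocarbon chain with two double bonds for a group with a furan ring, an amide hydrogen and a carbonyl, all at once, so this single pair cannot show which of these differences matters. Nothing measured here explains the drop in the number.

Going by these compounds, it remains open whether a saturated hydrocarbon chain such as decyl would hold the number of compound 2, which would show whether the double bonds matter, and whether a plain amine or a carboxylic acid at the end of the propyl chain would behave like the furan amide. A benzamide in place of the furan amide would likewise separate the role of the furan ring from that of the amide.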